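Vinyl sulfide chalcone analogues: growth inhibition of DU-145 cells

The compounds below may be only part of what the source reports. "The series", "measured", "known", "first", "only" and "open" are said of these compounds alone.

Measured so far:
- compound 1, `Cc1ccc(C)c(/C=C(/Sc2ccc(Br)cc2)C(=O)c2ccc(Cl)cc2)c1`: 10000 nM
- compound 2, `COc1ccccc1/C=C(/SCc1ccc(Cl)c(Cl)c1)C(=O)c1ccc(Cl)cc1`: 10000 nM

In a functional assay on DU-145 cells (Homo sapiens) for inhibition, read by trypan blue exclusion, with a stated time of 96 h (on this read-out higher numbers stand for weaker inhibition of growth and lower numbers for stronger inhibition of growth), compound 1 gives 10000 nM. In this assay compound 2 gives 10000 nM, which stands level with compound 1 at the digits shown; the two values lie within the scatter of each other, so neither can be called stronger or weaker. Both compounds share the same core and differ in the aromatic ring on the left and in the group carried on the sulfur, yet the read-out does not separate them.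

Compound 3, `COc1ccccc1/C=C(/Sc1ccc(Br)cc1)C(=O)c1ccc(Cl)cc1`, has not yet been measured in this assay. It differs from compound 2 in one place: 4-bromophenyl in place of 3,4-dichlorobenzyl on a sulfur. Among the measured compounds shown here, the group that enters is the one carried by compound 1 on its sulfur, so compound 3 combines the left-hand ring of compound 2 with the sulfur substituent of compound 1. For the measured compounds named here, with both measured compounds at the same value, no step of any size is apparent; the step from compound 2 to compound 3 is expected to be none beyond the scatter, no change at the digits printed from compound 2 to compound 3 (within the scatter). Because compound 2 gives 10000 nM and compound 1 gives 10000 nM, compound 3 is estimated at 10000 nM, within a range of 4000 nM to 25000 nM.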

Compound 3, concentration for 50% growth inhibition: 10000 nM
Beside the measured number, compound 3's estimate shows no gap at the digits printed; the range from low to high includes it.
By their numbers in this assay, from the lowest: compounds 1, 2 and 3 (each within the scatter of the next).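

Compounds 1 and 2 differ in two places, so their shared value could not be assigned to either place; compound 3 now allows each exchange to be read alone. In this assay, 4-bromophenyl in place of 3,4-dichlorobenzyl on a sulfur gives no change at the digits printed from compound 2 to compound 3 (within the scatter), so a direct aryl group and a benzyl group on this sulfur are not separated here, even with the two chlorines exchanged for one bromine. The second exchange, 2-methoxyphenyl in place of 2,5-dimethylphenyl on a double-bonded chain carbon bound to a double-bonded chain carbon, gives no change at the digits printed from compound 1 to compound 3 (within the scatter), and no measurement on hand offers an explanation for either result.

These three compounds cannot show whether any group on the sulfur or on the 2-methoxyphenyl ring would separate a compound from this shared value, for example an amine, a carboxylic acid or a longer chain on the sulfur. From the compounds shown here alone, the 4-chlorophenyl ketone part is common to all three compounds, so its contribution also remains open.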